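From trifluoromethyl to nitro on the shared core

A few compounds are considered here, and "the series" means these few. Any claim that something is new, unique, unknown or untested is made for them only; others in the source may bear on it.

Compound 1 (`Nc1nc2cc(Cl)c(Cl)cc2n1Cc1cccc(Cl)c1`) gives 65000 nM
Compound 2 (`Nc1nc2cc(Cl)c(Cl)cc2n1Cc1cccc(C(F)(F)F)c1`) gives 45000 nM

In a functional assay on KB cells (Homo sapiens) for inhibition (on this read-out lower numbers stand for stronger inhibition and higher numbers for weaker inhibition), compound 2 gives 45000 nM and cannot be told apart from compound 1 within the usual scatter. Compound 3 (`Nc1nc2cc(Cl)c(Cl)cc2n1Cc1cccc([N+](=O)[O-])c1`) carries nitro in place of trifluoromethyl on an aromatic carbon, meta to a large group (nitro in place of trifluoromethyl on an aromatic carbon). Going by the values given here, the one measured step that bears on this swap, a 1.4-fold lower number from compound 1 to compound 2 (0.16 log units; within the scatter) for trifluoromethyl in place of chloro on an aromatic carbon, stayed within the scatter. No step beyond the scatter is therefore expected in this assay, and the estimated change is small (a 1.1-fold higher number from compound 2 to compound 3 (0.05 log units; within the scatter)). For compound 3 the estimate is 50000 nM (18000 nM to 130000 nM as the expected range).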

Compound 3, half-maximal inhibitory concentration: 65000 nM
The estimate for compound 3 lay 1.3-fold (0.11 log units) below the measured number, within the range that was stated.
By their numbers in this assay, from the lowest: compounds 2, 1 and 3 (each within the scatter of the next).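

In this assay, nitro at this place on the aromatic ring gives no step beyond the scatter against either earlier group (a 1.4-fold higher number from compound 2 to compound 3 (0.16 log units; within the scatter); no change at the digits printed from compound 1 to compound 3 (within the scatter)). Chloro, trifluoromethyl and nitro therefore cannot be told apart here, even though nitro enters with hydrogen-bond acceptors that trifluoromethyl does not have by count. Nothing measured here offers an explanation for this result. From the compounds shown here alone, whether an amine, a carboxylic acid or a longer chain at this position would give a number beyond the scatter stays open.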